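The source may report more compounds than this note shows. Statements on the series, on what has been measured and on what is new or still open speak of the compounds shown alone.

Within the data shown here, in a functional assay on SW480 cells (Homo sapiens) for antiproliferative activity, read by MTT assay, with a stated time of 48 h (a higher number here means a weaker inhibitor, a lower number a stronger inhibitor), compound 2 (`CCCCCCCC(CCO)n1cnc2c(Cl)nc(F)nc21`) gives 26100 nM, the higher of the two numbers measured so far, while compound 1 (`CCCCCC(CCO)n1cnc2c(Cl)nc(Cl)nc21`) gives 6010 nM, a gap beyond the scatter. Compound 3 (`CCCCCCCC(CCO)n1cnc2c(Cl)nc(Cl)nc21`) departs from compound 2 by one change: chloro in place of fluoro on an aromatic carbon. Compound 3 thus carries chloro at the place where it also stands in compound 1, which has a different chain and gives 6010 nM, so a move toward that number is expected. The expected change is a 2.9-fold lower number from compound 2 to compound 3 (0.46 log units; beyond the scatter), toward a stronger inhibitor and beyond the scatter. Compound 3 is estimated at 9000 nM, with an expected range of 3500 nM to 24000 nM.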

Compound 3, half-maximal inhibitory concentration: 13600 nM
Beside the measured number, compound 3's estimate is 1.5-fold (0.18 log units) below it; the range from low to high includes it.
By their numbers in this assay, from the lowest: compound 1; then compounds 3 and 2 (each within the scatter of the next).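

At the aromatic carbon between two ring nitrogen atoms, chloro in place of fluoro gives a 1.9-fold lower number from compound 2 to compound 3 (0.28 log units; within the scatter) in this assay, so this halogen swap is not resolved on this chain. With chloro held at that carbon, ethyl in place of hydrogen on a saturated chain carbon, six bonds along the chain from an aromatic nitrogen, gives a 2.3-fold higher number from compound 1 to compound 3 (0.35 log units; beyond the scatter), a modest but readable step. No supporting measurement accounts for either step. Still open, as far as these compounds go, is how an amine at that aromatic carbon, or a longer chain, would read in this assay.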